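Shifting the Side Chain on a Purine Acetamide Series

This account rests on a few compounds, and the source may have more. Where it says the series, first, only, none or still open, it means among the compounds named here.

Four compounds sharing one core are followed in a functional assay on the whole organism (Tail, strain ICR) with Mus musculus as the target, in the tail flick test, with a stated time of 60 min, at a dose of 25 umol/kg by the oral route; on this read-out higher numbers stand for a stronger effect at the one dose given and lower numbers for a weaker effect. Compound 1 `C[C@@H](O)[C@H](NC(=O)CN(c1nc(Cl)nc2[nH]cnc12)C1CC1)C(=O)OCc1ccccc1` carries a 1-hydroxyethyl group on the chain carbon and a benzyl ester; in this assay compound 1 gives 29.7%. Compound 2 `NCCCC[C@H](NC(=O)CN(c1nc(Cl)nc2[nH]cnc12)C1CC1)C(=O)OCc1ccccc1` differs from compound 1 by 4-aminobutyl in place of 1-hydroxyethyl on a saturated chain carbon bound to an amide-type nitrogen and a carbonyl carbon; in this assay compound 2 gives 41.2%, and the step of a number 11.5 percentage points higher from compound 1 to compound 2 (beyond the scatter) is read as a modest gain. Compound 3 `C[C@@H](O)[C@H](NC(=O)CN(c1nc(Cl)nc2[nH]cnc12)C1CC1)C(=O)O` differs from compound 1 in the core by hydrogen in place of benzyl on an oxygen next to a carbonyl group; in this assay compound 3 gives 30.1%, so that the step of a number 0.4 percentage points higher from compound 1 to compound 3 (within the scatter) is too small to separate the two. Compound 4 `NCCCC[C@H](NC(=O)CN(c1nc(Cl)nc2[nH]cnc12)C1CC1)C(=O)O` has not yet been measured in this assay. Among the measured compounds shown here, it differs from compound 3 by 4-aminobutyl in place of 1-hydroxyethyl on a saturated chain carbon bound to an amide-type nitrogen and a carbonyl carbon, which is the same change as the one from compound 1 to compound 2, made at the same place on the free-acid core. Among the compounds shown this change occurs twice in all. He expects the step from compound 3 to compound 4 to be about a number 11.4 percentage points higher from compound 3 to compound 4 (beyond the scatter), because a number 11.5 percentage points higher from compound 1 to compound 2 (beyond the scatter) was the result of the same change on the benzyl-ester core, and the two cores stand within the scatter of each other. On that basis compound 4 is estimated at 41.5%, with an expected range from 31% to 52%.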

Compound 4, a percentage reported as activity, at one dose (the size of the read-out at that dose, not a potency): 53.8%
Compound 4: middle estimate off by 12.3 percentage points, on the low side, and the stated range ends below it.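

In this assay, among the compounds shown here, the change to 4-aminobutyl also raises the number on the free-acid core, with a number 23.7 percentage points higher from compound 3 to compound 4 (beyond the scatter), and this step and the one on the benzyl-ester core do not differ beyond what two such steps can scatter: the same change on two cores in this assay, a number 11.5 percentage points higher (beyond the scatter) from compound 1 to compound 2 and a number 23.7 percentage points higher (beyond the scatter) from compound 3 to compound 4, 12.2 percentage points apart, within the scatter of two such steps Removing the benzyl group gives a number 12.6 percentage points higher from compound 2 to compound 4 (beyond the scatter) on the 4-aminobutyl side, while on the 1-hydroxyethyl side it gives a number 0.4 percentage points higher from compound 1 to compound 3 (within the scatter), yet these two steps, too, cannot be told apart: the same change on two cores in this assay, a number 0.4 percentage points higher (within the scatter) from compound 1 to compound 3 and a number 12.6 percentage points higher (beyond the scatter) from compound 2 to compound 4, 12.2 percentage points apart, within the scatter of two such steps So the gain from 4-aminobutyl carried over in direction between these two cores, but with only one pair of steps for each change, the series does not show that the size of the gain is fixed, nor that the two changes reinforce each other, and it gives no reason for the high number of compound 4.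

The compounds shown leave open how the read-out would respond to a shorter or longer amine chain on the same carbon, or to a carboxylic acid at the end of that chain. They also leave open whether a smaller ester, such as an ethyl ester, would stand with the benzyl ester or with the free acid.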